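The source may report more compounds than this note shows. Statements on the series, on what has been measured and on what is new or still open speak of the compounds shown alone.

Compound 1 `CCOc1nc(-c2ccc(Cl)cc2Cl)c(CC)nc1NC(CC)CC`, 151 nM; compound 2 `CCCN(CC1CC1)c1nc(CC)c(-c2ccc(Cl)cc2Cl)nc1CC`, 19.2 nM; compound 3 `CCc1nc(-c2ccc(Cl)cc2Cl)c(CC)nc1NC(COC)COC`, 224 nM.

All three were measured in an assay on IMR-32 cells for displacement of a labelled ligand from corticotropin-releasing factor receptor 1 (Homo sapiens), read by scintillation counting, with a stated time of 2 h (a higher number here means a weaker inhibitor, a lower number a stronger inhibitor), and share one core. Compound 1 gives the second highest of the three numbers; its value and that of compound 3 lie within the scatter of each other, while compound 2 gives the lower number and stands beyond the scatter from compound 1. For the measured compounds named here, the only single-place step among them, a 12-fold higher number from compound 2 to compound 3 (1.07 log units; beyond the scatter), concerns a different place on the core and does not touch the change considered here. Compound 4 `CCc1nc(NC(CC)CC)c(OC)nc1-c1ccc(Cl)cc1Cl` differs from compound 1 by hydrogen in place of methyl on a saturated chain carbon bound to an oxygen on an aromatic ring. Going by the values given here, no measured step bears on this change, so compound 4 is expected to stay close to compound 1, a 1.1-fold higher number from compound 1 to compound 4 (0.05 log units; within the scatter). Compound 4 is therefore estimated at 170 nM, between 70 nM and 420 nM.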

Compound 4, inhibition constant: 5.9 nM
Compound 4: the middle estimate sits 29-fold (1.46 log units) above what was measured; the whole stated range lies above it.
By their numbers in this assay, from the lowest: compound 4; then compound 2; then compounds 1 and 3 (each within the scatter of the next).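

In this assay, for the compounds shown here, going from ethoxy to methoxy gives a 26-fold lower number from compound 1 to compound 4 (1.41 log units; beyond the scatter) and so shows that this place on the shared core, which no earlier step touched, is highly sensitive to the loss of a single methyl. Nothing available explains the size of this step.

The compounds shown leave open how a hydroxyl, a longer propoxy chain or an amine would read at this place. They also leave open whether the change from ethoxy to methoxy would have the same size alongside the (cyclopropylmethyl)(propyl)amino group of compound 2.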